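Notes on three measured compounds and one candidate

The source may report more compounds than this note shows. Statements on the series, on what has been measured and on what is new or still open speak of the compounds shown alone.

In a functional assay on RAW264.7 cells (Mus musculus) for inhibition, read by Griess assay, with a stated time of 24 h (a higher number here means a weaker inhibitor, a lower number a stronger inhibitor), compound 1 `CN(C[C@H](O)[C@@H](O)[C@H](O)[C@H](O)CO)C(=S)NCc1ccccc1` gives only a limit, >= 200000 nM. In this assay compound 2 `COc1cc(NC(=S)Nc2ccccc2)cc(OC)c1OC` gives 15200 nM. In this assay compound 3 `O=C(NNC(=S)NCc1ccccc1)c1ccccc1` likewise gives only a limit, >= 200000 nM. Compound 3 therefore stands at the limit rather than at a number, and that limit is shared with compound 1 (the limit of >= 200000 nM in this assay, at which 2 of the 3 values shown sit). Compound 4 `O=C(NNC(=S)NCc1ccccc1)c1ccncc1` is not yet measured. It differs from compound 3 by pyridin-4-yl in place of phenyl on a carbonyl carbon. Going by the values given here, no step between measured compounds is known, so nothing measured sets the size of this change. The step from compound 3 to compound 4 is expected to be a number no higher from compound 3 to compound 4 (the limit leaves the size open), none beyond the scatter. Compound 4 is accordingly estimated at 200000 nM, within 40000 nM to 200000 nM.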

Compound 4, half-maximal inhibitory concentration: 7400 nM
Estimate against measurement, compound 4: 27-fold (1.43 log units) above; measured number below the stated range.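

In this assay, going by these compounds alone, pyridin-4-yl in place of phenyl on a carbonyl carbon gives an at least 27-fold lower number from compound 3 to compound 4 (1.43 log units; beyond the scatter), the only measured step, so this position can move the read-out beyond the scatter. By count, the change adds one hydrogen-bond acceptor and leaves the number of heavy atoms the same. The full size of the step stays open because compound 3 is a limit and not a number: the limit of >= 200000 nM in this assay, at which 2 of the 4 values shown sit.

The compounds shown do not say whether the ring nitrogen alone accounts for the step. A pyrimidinyl ring or an aminophenyl group on that carbonyl carbon would test this.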